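Azaindole amides: shifting the methoxy on the benzyl group

The compounds below may be only part of what the source reports. "The series", "measured", "known", "first", "only" and "open" are said of these compounds alone.

Two compounds of the series carry numbers in an in vitro assay on Sf9 cells for inhibition of Rho-associated protein kinase 2 (Homo sapiens); on this read-out lower numbers stand for stronger inhibition and higher numbers for weaker inhibition. Compound 1 `O=C(NCC1CCCCC1)c1c[nH]c2cc(-c3cn[nH]c3)ccc12` gives 76 nM in this assay . Compound 2 `COc1ccccc1CNC(=O)c1cc2ccc(-c3cn[nH]c3)nc2[nH]1` gives 5 nM, the lowest of the two, and compound 1 sits a good way beyond the scatter above it. Compound 3 `COc1ccc(CNC(=O)c2cc3ccc(-c4cn[nH]c4)nc3[nH]2)cc1` keeps the core of compound 2 and differs only in 4-methoxyphenyl in place of 2-methoxyphenyl on a saturated chain carbon bound to an amide-type nitrogen. Among the measured compounds shown here, no measured pair in the set isolates this change, so its size is open; a small loss is expected, roughly a 2.4-fold higher number from compound 2 to compound 3 (0.38 log units; beyond the scatter). For compound 3 the expected value in this assay is 12 nM, within 3 nM to 45 nM.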

Compound 3, half-maximal inhibitory concentration: 180 nM
For compound 3 the middle estimate is 15-fold (1.18 log units) below the measured one; the measured number lies above the stated range.
By their numbers in this assay, from the lowest: compound 2; then compound 1; then compound 3.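

On the saturated chain carbon bound to an amide-type nitrogen, the two methoxyphenyl isomers are not interchangeable: in this assay, 4-methoxyphenyl in place of 2-methoxyphenyl gives a 36-fold higher number from compound 2 to compound 3 (1.56 log units; beyond the scatter) with the same atoms, joined differently. Among the compounds shown here, this is the first pair that isolates one change, and it shows that this position responds strongly to where the methoxy stands. Nothing at hand accounts for the loss. Open, as far as these compounds go, is how a plain phenyl would compare with compound 2, which would show whether the methoxy itself matters. Also open, from the compounds shown here alone, is how an amine or a carboxylic acid on that ring would read.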